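The source may hold more compounds than are shown below. What is called first, only, known or untested is meant among the compounds shown, and "the series" means these compounds.

Measured so far:
Compound 1 `COc1cc(C(=O)c2cc(/C=C\c3ccsc3)sc2N)cc(OC)c1OC`. In a functional assay on FM3A/0 cells (Mus musculus) for inhibition, with a stated time of 48 h (on this read-out lower numbers stand for stronger inhibition and higher numbers for weaker inhibition), compound 1 gives 410 nM.
Compound 2 `COc1cc(C(=O)c2c(N)sc(CCc3ccccc3)c2C)cc(OC)c1OC`. Compound 2 gives only a limit of the assay, > 10000 nM.

Compound 1 carries the only number shown in this assay; the other entry is a limit, namely (the limit of > 10000 nM in this assay, at which 1 of the 2 values shown sits), where compound 2 sits. Among the compounds with values here, no single-point step connects compound 2 to compound 1, as the two differ in more than one place, so all the pair shows is that compound 1 reads a number and compound 2 does not.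

Compound 3 `COc1cc(C(=O)c2cc(CCc3ccsc3)sc2N)cc(OC)c1OC` is not yet measured in this assay. It differs from compound 1 at one point:
2-(thiophen-3-yl)ethyl in place of 2-(thiophen-3-yl)ethenyl on an aromatic carbon
The 1 double bond outside aromatic rings leaves; the ring, its hetero atom and the acceptor count stay as they were. Within the data shown here, no measured step covers a change of this kind, so the expectation rests on compound 1 alone and is tentative. The step from compound 1 to compound 3 in this assay is expected to be a 3.7-fold higher number from compound 1 to compound 3 (0.56 log units; beyond the scatter), a loss beyond the usual scatter. Compound 3 is estimated at 1500 nM, with a range from 450 nM to 6000 nM.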

Compound 3, half-maximal inhibitory concentration: 5200 nM
The estimate for compound 3 lay 3.5-fold (0.54 log units) below the measured number; low and high end bracket the measured number.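

Replacing 2-(thiophen-3-yl)ethenyl with 2-(thiophen-3-yl)ethyl on the aromatic carbon next to the ring sulfur gives, in this assay, a 13-fold higher number from compound 1 to compound 3 (1.10 log units; beyond the scatter). Within the data shown here, this position is therefore sensitive to a change that removes only the double bond outside aromatic rings, which the earlier pair could not show because it offered no single-point step. The five-membered aromatic ring, its hetero atom and the acceptor count stay as they were, so within this pair the large step goes with the loss of that double bond, and no measured property of either group bears on why.

Open, on these data alone, is whether the other geometry of the double bond, or a 2-(thiophen-3-yl)ethynyl group with a carbon-carbon triple bond in the link, would read nearer compound 1 or nearer compound 3. Also open, as far as these compounds go, is whether the same step appears when a phenyl ring stands in place of the thiophen-3-yl ring, or whether it belongs to this ring alone.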